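The source may report more compounds than this note shows. Statements on the series, on what has been measured and on what is new or still open speak of the compounds shown alone.

In a physicochemical assay for lipophilicity, at pH 7.4 (on this read-out lower numbers stand for lower lipophilicity and higher numbers for higher lipophilicity), compound 1 (`CC(C)CN(C1CCc2ccc(F)cc21)S(=O)(=O)c1ccc2c(c1)C(=O)CC(C1CCOCC1)O2`) gives 4.03 as the lowest of three measured numbers. Compound 2 (`CCc1ccc(N(CC(C)C)S(=O)(=O)c2ccc(OCC3CCOCC3)c3c2CCCC3=O)cc1`) gives 4.84 and compound 3 (`CCc1ccc(N(Cc2ccccc2)S(=O)(=O)c2ccc3c(c2)C(=O)CC(C2CCOCC2)O3)cc1`) gives 4.84 as well, both beyond the scatter from compound 1. Compound 4 (`CC(C)CN(c1ccc(C(C)(C)C)cc1)S(=O)(=O)c1ccc2c(c1)C(=O)CC(C1CCOCC1)O2`) takes 4-(tert-butyl)phenyl in place of 6-fluoro-2,3-dihydro-1H-inden-1-yl on a sulfonamide nitrogen. Among the compounds with values here, no measured pair isolates this change, so the expectation is a rough one. Compound 1 shares its core with compound 3 at 4.84 on the same read-out, which suggests a rise beyond the scatter in this assay for this change. The expected size is a number 0.77 log units higher from compound 1 to compound 4 (beyond the scatter) upward. Compound 4 is estimated at 4.8 within an expected range of 4.4 to 5.2 once it is measured.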

Compound 4, distribution coefficient: 4.97
Compound 4: the middle estimate sits 0.17 log units below what was measured; the measured number falls inside the stated range.
By their numbers in this assay, from the lowest: compound 1; then compounds 2, 3 and 4 (each within the scatter of the next).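

Within the data shown here, on the sulfonamide nitrogen, 4-(tert-butyl)phenyl in place of 6-fluoro-2,3-dihydro-1H-inden-1-yl gives in this assay a number 0.94 log units higher from compound 1 to compound 4 (beyond the scatter) and provides the only step here that isolates one place. The two groups have the same heavy-atom count and no hydrogen-bond donors or acceptors, yet the step lies beyond the scatter. Nothing available accounts for its cause. On these data alone, whether the step would persist on another core remains open. So does how a group carrying an amine or a carboxylic acid would read at this position.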